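A few compounds are considered here, and "the series" means these few. Any claim that something is new, unique, unknown or untested is made for them only; others in the source may bear on it.

Measured so far in a functional assay on EL4 cells (Mus musculus) for inhibition, tested at 100 uM; on this read-out lower numbers stand for less inhibition and higher numbers for more inhibition at the one concentration tested (going by the name of the read-out):
- compound 1 `OCCNc1[nH]ccc2ncnc1-2`: < 5% (a limit of the assay, not a number)
- compound 2 `CN(C)c1[nH]ccc2ncnc1-2`: 25%
- compound 3 `CNc1[nH]ccc2ncnc1-2`: < 5% (a limit of the assay, not a number)

Compound 3 stands at the lower limit of this assay; compound 2 is the only one of the three with a numbered value, and the step of a number at least 20 percentage points lower from compound 2 to compound 3 (beyond the scatter) is read against that value. For compound 1 the assay likewise gives only a limit. The step of a number at least 20 percentage points higher from compound 1 to compound 2 (beyond the scatter) runs in the same sense, so the dimethylamino compound 2 stands apart from both compounds that carry a hydrogen on the amino nitrogen. The step that the two limits leave unreadable from compound 1 to compound 3 cannot be sized, as the limit of < 5% in this assay, at which 2 of the 3 values shown sit, holds both ends.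

Compound 4 `CSc1[nH]ccc2ncnc1-2` is not yet measured. The change from compound 3 is methylsulfanyl in place of methylamino on an aromatic carbon. Going by the values given here, no measured step exchanges the nitrogen for sulfur, so the closest guidance is that the only numbered value, for compound 2, is modest and that both donor-bearing compounds sit at the limit. The expected step of a number at least 5 percentage points higher from compound 3 to compound 4 (that floor lies within the scatter) is therefore small, most likely within the scatter, with a chance that compound 4 again reports only a limit. Compound 4 is estimated at 10%, within 0% to 30%.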

Compound 4, a percentage reported as inhibition, at one concentration (the size of the read-out at that concentration, not a potency): < 5%
Compound 4: a limit, no number (the forecaster's own chance of this, stated with the estimate: 45%); at least 5 percentage points between middle value and limit.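

In this assay compound 4 gives < 5%, a limit of the assay and not a number. Methylsulfanyl carries 0 hydrogen-bond donors, like the dimethylamino group of compound 2, whose nitrogen bears no hydrogen, yet the series shows a number at least 20 percentage points lower from compound 2 to compound 4 (beyond the scatter), so on this aromatic carbon the absence of a donor in the group does not by itself go with the value of compound 2, and compound 2 remains the only compound of the four above the limit. The steps among compound 1, compound 3 and compound 4 cannot be read, as both ends of each are limits: the limit of < 5% in this assay, at which 3 of the 4 values shown sit.

On these data alone, whether the value of compound 2 is tied to dimethylamino in particular, or would carry over to diethylamino or to a ring amine such as pyrrolidine or morpholine, stays open. Also open, as far as these compounds go, is how methoxy, with oxygen in place of the sulfur of compound 4, would read on the same aromatic carbon, and whether any difference among the compounds at the limit exists at all.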